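A trifluoromethyl added to a series held at the limit

A few compounds are considered here, and "the series" means these few. Any claim that something is new, unique, unknown or untested is made for them only; others in the source may bear on it.

Compound 3 `O=C(Nc1ccc(Cl)cc1)Nc1cccc(-c2nc(-c3ccc(NC(=O)c4cccnc4)cc3Cl)no2)c1` is the starting point. In a functional assay on MDA-MB-231 cells (Homo sapiens) for antiproliferative activity, read by MTT assay, with a stated time of 72 h (on this read-out higher numbers stand for weaker inhibition and lower numbers for stronger inhibition), compound 3 gives only a limit, > 10000 nM, and not a number. Its two neighbours stand in the same place. Compound 1 `Cc1ccc(S(=O)(=O)Nc2cccc(-c3nc(-c4ccc(NC(=O)c5cccnc5)cc4Cl)no3)c2)cc1` gives a limit of > 10000 nM in this assay. Compound 2 `COc1cccc(S(=O)(=O)Nc2cccc(-c3nc(-c4ccc(NC(=O)c5cccnc5)cc4Cl)no3)c2)c1` likewise gives a limit of > 10000 nM. Every measured value thus sits at the limit of > 10000 nM in this assay, at which 3 of the 3 values shown sit, and the steps a step that the two limits leave unreadable from compound 1 to compound 2, a step that the two limits leave unreadable from compound 1 to compound 3 and a step that the two limits leave unreadable from compound 2 to compound 3 cannot be read in size or direction. Compound 4 `O=C(Nc1cccc(-c2nc(-c3ccc(NC(=O)c4cccnc4)cc3Cl)no2)c1)Nc1ccc(Cl)c(C(F)(F)F)c1` differs from compound 3 by trifluoromethyl in place of hydrogen on an aromatic carbon. Going by the values given here, none of the measured steps concerns a change on the 4-chlorophenyl group, and none has a readable size, so they offer no guidance beyond showing that the whole set has so far stayed at the limit. The step of an at least 1.1-fold lower number from compound 3 to compound 4 (0.04 log units; that floor lies within the scatter) is therefore expected to be none beyond the scatter, with another limit the likeliest outcome. Compound 4 is estimated at 9000 nM, between 2000 nM and 30000 nM.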

Compound 4, half-maximal inhibitory concentration: 1900 nM
Compound 4: the middle estimate sits 4.7-fold (0.68 log units) above what was measured; measured number outside the range, below it.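

In this assay, going by these compounds alone, adding trifluoromethyl to the 4-chlorophenyl group gives an at least 5.2-fold lower number from compound 3 to compound 4 (0.72 log units; beyond the scatter), and this is the first step in the set with a readable size and direction. The earlier steps all ran between limits and could not be read, and none of them was a change on the 4-chlorophenyl group, so this position is the first shown to respond to a substituent. Compound 4 is the only compound shown with a number, while the others remain at one place: the limit of > 10000 nM in this assay, at which 3 of the 4 values shown sit.

The compounds shown leave open whether trifluoromethyl is specifically required at this position or whether a nitrile or a fluoro group there would give a similar step, and whether the step persists without the chloro group. They also leave open whether the same addition would bring the sulfonyl compounds, compound 1 and compound 2, to a measurable number.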